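The source may hold more compounds than are shown below. What is called first, only, known or untested is meant among the compounds shown, and "the series" means these compounds.

In a physicochemical assay for pharmacokinetics (on this read-out higher numbers stand for a longer-lived compound and lower numbers for a shorter-lived compound), compound 1 (`O=C(NCc1ccccc1F)N1C(=O)c2ccccc2S1(=O)=O`) gives > 166 h, and this is a limit of the assay, not a number. Its close relative, compound 2 (`O=C(NCc1cccc(Br)c1)N1C(=O)c2ccccc2S1(=O)=O`), gives > 166 h, which is also a limit. The evidence so far is therefore thin: the limit of > 166 h in this assay, at which 2 of the 2 values shown sit. Within the data shown here, the only measured step is a step that the two limits leave unreadable from compound 1 to compound 2, so it offers no size to carry forward.

Compound 3 (`O=C(NCc1ccccc1C(F)(F)F)N1C(=O)c2ccccc2S1(=O)=O`) has not yet been measured. It keeps the core of compound 1 and changes one group: trifluoromethyl in place of fluoro on an aromatic carbon. This places trifluoromethyl in place of fluoro on an aromatic carbon, ortho to a large group.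

With no readable step to draw on, no step beyond the usual scatter is expected in this assay, and no direction can be favoured. This expectation rests on the limit of compound 1 at > 166 h. A further limit rather than a number is the likeliest report for the new compound. The expected change is a step that the limit leaves unreadable from compound 1 to compound 3. The estimate for compound 3 is 170 h, with an expected range from 90 h to 300 h.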

Compound 3, half-life: > 166 h
Compound 3 gave a limit, no number; the forecaster's own chance of this, stated with the estimate: 80%; the middle value is on the limit's open side.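

In this assay, compound 3 and compound 1 each give only a limit, not a number, so no step can be read between them. All the results shown stop at the same point: the limit of > 166 h in this assay, at which 3 of the 3 values shown sit. On these data alone, what remains open is the actual half-life of each compound, and whether trifluoromethyl in place of fluoro changes it at all.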